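From methoxy to hydroxy in compound 4

The source may report more compounds than this note shows. Statements on the series, on what has been measured and on what is new or still open speak of the compounds shown alone.

Measured in a functional assay on NCI-H157 cells (Homo sapiens) for cytotoxicity, read by resazurin assay, with a stated time of 72 h; a higher number here means a weaker inhibitor, a lower number a stronger inhibitor:
Compound 1 (`COc1cc(/C=C/C(=O)OCCCO[N+](=O)[O-])ccc1OCCCO[N+](=O)[O-]`) gives > 50000 nM, which is a limit of the assay.
Compound 2 (`COc1cc(/C=C/C(=O)OC(C)CCOc2no[n+]([O-])c2S(=O)(=O)c2ccccc2)ccc1O`) gives 410 nM.
Compound 3 (`COc1cc(/C=C/C(=O)OCCCO[N+](=O)[O-])ccc1O`) gives 20500 nM.

Compound 1 has no number, only (the limit of > 50000 nM in this assay, at which 1 of the 3 values shown sits). Compound 4 (`O=C(/C=C/c1ccc(OCCCO[N+](=O)[O-])c(O)c1)OCCCO[N+](=O)[O-]`) is compound 1 with a single change, (hydrogen in place of methyl on an oxygen on an aromatic ring), that is, hydrogen in place of methyl on an oxygen on an aromatic ring, or methoxy to hydroxy. For the measured compounds named here, one measured step bears on it, though only indirectly. That step also places hydrogen on an oxygen on an aromatic ring, but it removes 3-(nitrooxy)propyl rather than methyl, and it amounts to an at least 2.4-fold lower number from compound 1 to compound 3 (0.38 log units; beyond the scatter). Compound 2 differs from compound 1 in more than one place and offers no direct guide. On this single precedent from compound 3, the expected step is an at least 2.2-fold lower number from compound 1 to compound 4 (0.35 log units; beyond the scatter), a modest one toward a lower number in this assay, although a reading at the limit remains possible. Compound 4 is estimated at 22000 nM, with an expected range from 8000 nM to 50000 nM.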

Compound 4, half-maximal inhibitory concentration: 5710 nM
For compound 4 the middle estimate is 3.9-fold (0.59 log units) above the measured one; measured number below the stated range.
By their numbers in this assay, from the lowest: compound 2; then compound 4; then compound 3. At a limit, above all of these: compound 1.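

In this assay, hydrogen in place of methyl on an oxygen on an aromatic ring gives an at least 8.7-fold lower number from compound 1 to compound 4 (0.94 log units; beyond the scatter). For the compounds shown here, the only earlier step of this kind removed 3-(nitrooxy)propyl, so this result adds that methoxy to hydroxy also lowers the number, with both 3-(nitrooxy)propyl chains still present. Compound 1 stands at a limit, so the full size of this step stays unknown: the limit of > 50000 nM in this assay, at which 1 of the 4 values shown sits.

The compounds shown leave open whether the gain needs the free hydroxy itself, or whether an ethoxy group or an amine at the same place would give a similar number. They also leave open whether methoxy to hydroxy would lower the number by a similar amount in compound 2, which carries a different ester chain.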